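Chloro for methyl on the indole ring: next step

The source may report more compounds than this note shows. Statements on the series, on what has been measured and on what is new or still open speak of the compounds shown alone.

Measured in a functional assay on HeLa cells (Homo sapiens) for inhibition, read by sulforhodamine B assay, with a stated time of 48 h; a higher number here means a weaker inhibitor of growth, a lower number a stronger inhibitor of growth:
compound 1 `COC(=O)[C@@]1(C)CCC=C2[C@@H]1CC[C@@H](C)[C@]2(C)Cc1c[nH]c2c(C)cccc12` gives 4900 nM
compound 2 `COC(=O)[C@@]1(C)CCC=C2[C@@H]1CC[C@@H](C)[C@]2(C)Cc1c[nH]c2c(Cl)cccc12` gives 14000 nM
compound 3 `COC(=O)[C@@]1(C)CCC=C2[C@@H]1CC[C@@H](C)[C@]2(C)Cc1c(C)[nH]c2c(C)cccc12` gives 14000 nM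

Compound 3 stands level with compound 2 at the digits printed, the two together holding the highest numbers of the three; compound 1 lies furthest off, with a 2.9-fold higher number from compound 1 to compound 3 (0.46 log units; beyond the scatter) on going to compound 3. Compound 4 `COC(=O)[C@@]1(C)CCC=C2[C@@H]1CC[C@@H](C)[C@]2(C)Cc1c(C)[nH]c2c(Cl)cccc12` is the not yet measured member; against compound 3 the change is chloro in place of methyl on an aromatic carbon. For the measured compounds named here, the one measured step of the same kind, a 2.9-fold higher number from compound 1 to compound 2 (0.46 log units; beyond the scatter), was modest and beyond the scatter. A step of similar size and direction in this assay is expected here, so compound 4 is estimated at 38000 nM with a range from 14000 nM to 100000 nM. This corresponds to an expected 2.7-fold higher number from compound 3 to compound 4 (0.43 log units; beyond the scatter).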

Compound 4, concentration for 50% growth inhibition: 17000 nM
The estimate for compound 4 lay 2.2-fold (0.35 log units) above the measured number; low and high end bracket the measured number.
By their numbers in this assay, from the lowest: compound 1; then compounds 2, 3 and 4 (each within the scatter of the next).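

In this assay, chloro in place of methyl on an aromatic carbon gives a 1.2-fold higher number from compound 3 to compound 4 (0.08 log units; within the scatter), so the earlier step beyond the scatter does not recur on this core, though the two readings cannot be separated: the same change on two cores in this assay, a 2.9-fold higher number (0.46 log units; beyond the scatter) from compound 1 to compound 2 and a 1.2-fold higher number (0.08 log units; within the scatter) from compound 3 to compound 4, 2.4-fold (0.37 log units) apart, within the scatter of two such steps

Methyl in place of hydrogen on an aromatic carbon, with chloro already present, gives a 1.2-fold higher number from compound 2 to compound 4 (0.08 log units; within the scatter), and the same holds: the same change on two cores in this assay, a 2.9-fold higher number (0.46 log units; beyond the scatter) from compound 1 to compound 3 and a 1.2-fold higher number (0.08 log units; within the scatter) from compound 2 to compound 4, 2.4-fold (0.37 log units) apart, within the scatter of two such steps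

Neither change is thus shown to depend on its core.

The compounds shown leave open how an amine or a carboxylic acid on this aromatic carbon would read. From the compounds shown here alone, a longer chain in place of the methyl also remains open.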